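The source may hold more compounds than are shown below. What is called first, only, known or untested is meant among the compounds shown, and "the series" means these compounds.

Compound 1, `Cc1ccccc1-c1cc2cc(CCC(=O)O)ccc2[nH]1`, gives 447 nM in a functional assay on CHO cells for agonist activity at Free fatty acid receptor 1 (Homo sapiens), read by a luciferase reporter, with a stated time of 24 h; a higher number here means that more compound is needed for the effect, a lower number that less compound is needed. Compound 3, `O=C(O)CCc1ccc2[nH]c(-c3ccccc3C(F)(F)F)cc2c1`, differs from it by trifluoromethyl in place of methyl on an aromatic carbon, and in this assay compound 3 gives 1310 nM, a change of a 2.9-fold higher number from compound 1 to compound 3 (0.47 log units; beyond the scatter). Compound 2, `COc1cccc(-c2cc3cc(CCC(=O)O)ccc3[nH]2)c1`, is recorded in this assay only as a limit, > 25 nM, not as a number. Among the two numbers given, compound 3 thus stands highest, with compound 1 nearest at a lower number.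

Compound 4, `COc1ccccc1-c1cc2cc(CCC(=O)O)ccc2[nH]1`, is to be measured next. It differs from compound 3 by methoxy in place of trifluoromethyl on an aromatic carbon. Going by the values given here, the one measured step that bears on this position is the move from compound 1 to compound 3, which raised the number by a 2.9-fold higher number from compound 1 to compound 3 (0.47 log units; beyond the scatter). Replacing trifluoromethyl with a smaller methoxy group at the same place is expected to move the number back toward that of compound 1, so a modest fall is expected, a 2.9-fold lower number from compound 3 to compound 4 (0.46 log units; beyond the scatter). For compound 4 the value in this assay is therefore estimated at 450 nM, with a range from 150 nM to 1300 nM.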

Compound 4, half-maximal effective concentration: > 25 nM
Compound 4: a limit, no number; the forecaster's own chance of this, stated with the estimate: 10%; the middle value is on the limit's open side.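

Compound 4 is recorded in this assay only as a limit, > 25 nM, so its steps from compound 3 and from compound 1 cannot be read. The same limit recurs among the compounds shown: the limit of > 25 nM in this assay, at which 2 of the 4 values shown sit. The compounds shown leave open whether methoxy gives a higher or lower number than methyl or trifluoromethyl at this place.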